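A few compounds are considered here, and "the series" means these few. Any claim that something is new, unique, unknown or untested is made for them only; others in the source may bear on it.

In a functional assay on A549 cells (Homo sapiens) for antiproliferative activity (a higher number here means a weaker inhibitor, a lower number a stronger inhibitor), the following have been measured:
Compound 1 `COC(=O)CCNC(=O)[C@H]1CC=C(CCC=C(C)C)C[C@@H]1c1ccccc1` gives 87900 nM
Compound 2 `CON(C)C(=O)[C@H]1CC=C(CCC=C(C)C)C[C@@H]1c1ccccc1` gives 31200 nM
Compound 3 `CC(C)=CCCC1=CC[C@H](C(=O)NO)[C@@H](c2ccccc2)C1` gives 71700 nM

Compound 3 stands within the scatter of compound 1 and higher than compound 2, as a 2.3-fold higher number from compound 2 to compound 3 (0.36 log units; beyond the scatter) shows. In compound 4 `CC(C)=CCCC1=CC[C@H](C(=O)O)[C@@H](c2ccccc2)C1`, hydroxy takes the place of hydroxyamino on a carbonyl carbon (hydroxy in place of hydroxyamino on a carbonyl carbon). All three measured steps change the same carbonyl substituent: a 2.8-fold lower number from compound 1 to compound 2 (0.45 log units; beyond the scatter), a 1.2-fold lower number from compound 1 to compound 3 (0.09 log units; within the scatter) and a 2.3-fold higher number from compound 2 to compound 3 (0.36 log units; beyond the scatter). They are modest or smaller, though none of them introduces hydroxy. No large change is therefore expected in this assay, and the expected step is a 1.2-fold lower number from compound 3 to compound 4 (0.08 log units; within the scatter). Compound 4 is estimated at 60000 nM, with an expected range from 25000 nM to 140000 nM.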

Compound 4, half-maximal inhibitory concentration: 53700 nM
Beside the measured number, compound 4's estimate is 1.1-fold (0.05 log units) above it, within the range that was stated.
By their numbers in this assay, from the lowest: compounds 2, 4, 3 and 1 (each within the scatter of the next, the first and the last beyond it).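

Putting hydroxy in place of hydroxyamino on a carbonyl carbon keeps the number in this assay within the scatter (a 1.3-fold lower number from compound 3 to compound 4 (0.13 log units; within the scatter)). The carboxy compound also lies within the scatter of the two other carbonyl substituents (a 1.7-fold higher number from compound 2 to compound 4 (0.24 log units; within the scatter)) and (a 1.6-fold lower number from compound 1 to compound 4 (0.21 log units; within the scatter)), so at this position a substituent without nitrogen gives no difference beyond the scatter from any of the three nitrogen-bearing ones. Nothing available explains this result.

Going by these compounds, whether a methyl ester or a primary amide on this carbonyl carbon would move the number beyond the scatter stays open. So does the effect of changing the shared core.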